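From 3-bromobenzyl to 3,4-dichlorobenzyl on compound 3

This account rests on a few compounds, and the source may have more. Where it says the series, first, only, none or still open, it means among the compounds named here.

Measured so far in a functional assay on MCF7 cells (Homo sapiens) for cytotoxicity, read by sulforhodamine B assay, with a stated time of 72 h; a higher number here means a weaker inhibitor, a lower number a stronger inhibitor:
compound 1 `O=C(Nc1ccc(Nc2ncnc3c2cnn3-c2ccccc2)cc1)Nc1cccc(Br)c1` gives 36300 nM
compound 2 `O=C(Nc1ccccc1)Nc1ccc(Oc2ncnc3c2cnn3-c2ccc(Cl)cc2)cc1` gives 82500 nM
compound 3 `O=c1sc2cc(Nc3ncnc4c3cnn4-c3ccccc3)ccc2n1Cc1cccc(Br)c1` gives 46100 nM

In this assay compound 3 stands at 46100 nM and lies within the scatter of both other compounds, so the three values show no order. Compound 4 `O=c1sc2cc(Nc3ncnc4c3cnn4-c3ccccc3)ccc2n1Cc1ccc(Cl)c(Cl)c1`, not yet measured, has 3,4-dichlorophenyl in place of 3-bromophenyl on a saturated chain carbon bound to an aromatic nitrogen and is otherwise the same as compound 3. Among the compounds with values here, no two measured compounds differ in one place only, so the data offer no direct precedent for this change. With only that spread to go on, no step beyond the scatter is expected in this assay. The expected 1.2-fold lower number from compound 3 to compound 4 (0.08 log units; within the scatter) therefore stays within the scatter. For compound 4 the estimated value is 38000 nM (range 14000 nM to 90000 nM).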

Compound 4, half-maximal inhibitory concentration: 1600 nM
The estimate for compound 4 lay 24-fold (1.38 log units) above the measured number; measured number outside the range, below it.
By their numbers in this assay, from the lowest: compound 4; then compounds 1, 3 and 2 (each within the scatter of the next, the first and the last beyond it).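

In this assay, within the data shown here, the change from 3-bromobenzyl to 3,4-dichlorobenzyl gives a 29-fold lower number from compound 3 to compound 4 (1.46 log units; beyond the scatter) and thus the first step beyond the scatter among compounds differing in one place. It shows that the aryl group on a saturated chain carbon bound to an aromatic nitrogen can strongly shift the number, even though the rest of the molecule stays the same. No measurement at hand explains this step. The compounds shown leave open whether both chlorines are needed or the loss of bromine alone accounts for the step. They also leave open whether a methoxy group on this ring or a longer chain in place of the benzyl link would keep it.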